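Acetyl in Place of Benzoyl: Expectation for Compound 4

A few compounds are considered here, and "the series" means these few. Any claim that something is new, unique, unknown or untested is made for them only; others in the source may bear on it.

Measured compounds:
- compound 1, `N#C/C(=C\c1c(-c2ccccc2)[nH]c2ccccc12)C(=O)c1ccccc1`: 3500 nM
- compound 3, `COc1ccc(-c2[nH]c3ccc(OC)cc3c2/C=C(\C#N)S(=O)(=O)c2ccccc2)cc1`: 632 nM
- compound 2, `O=C(/C(=C\c1c(-c2ccccc2)[nH]c2ccccc12)S(=O)(=O)c1ccccc1)c1ccccc1`: "not determined" (no result reported)

In a functional assay on HCT-15 cells (Homo sapiens) for inhibition, read by sulforhodamine B assay, with a stated time of 48 h (a higher number here means a weaker inhibitor of growth, a lower number a stronger inhibitor of growth), compound 1 gives 3500 nM, and compound 3 gives 632 nM. For compound 2, which bears both a benzoyl and a phenylsulfonyl group on the double-bonded chain carbon, the result in this assay is "not determined" (no result reported), so it stands on no number at all. Compound 4, `CC(=O)/C(=C\c1c(-c2ccccc2)[nH]c2ccccc12)S(=O)(=O)c1ccccc1`, differs from compound 2 in one place: methyl in place of phenyl on a carbonyl carbon. With no value for compound 2, and no pair of measured compounds differing in this group alone, the size of this step in this assay cannot be read from the data; the shown values of compound 1 and compound 3 only mark out the range in which members of this series have fallen. On that basis, compound 4 is expected to lie within that span, and its estimated value in this assay is 2000 nM, with a likely range from 400 nM to 10000 nM.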

Compound 4, concentration for 50% growth inhibition: 836 nM
Beside the measured number, compound 4's estimate is 2.4-fold (0.38 log units) above it; measured number inside the range.
By their numbers in this assay, from the lowest: compounds 3 and 4 (each within the scatter of the next); then compound 1.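

For the compounds shown here, with no single number for compound 2 in this assay, no step from compound 2 to compound 4 can be read. The compounds shown leave open what the change from benzoyl to acetyl alone does to growth inhibition. Nothing shown bears on the reason for the value of compound 4.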